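From compound 2 to compound 3: losing the pyridin-4-yl ring

The source may hold more compounds than are shown below. What is called first, only, known or untested is meant among the compounds shown, and "the series" means these compounds.

Measured so far in a functional assay on KB cells (Homo sapiens) for antiproliferative activity, read by sulforhodamine B assay, with a stated time of 3 days (on this read-out higher numbers stand for weaker inhibition of growth and lower numbers for stronger inhibition of growth), and shown here
Compound 1 `O=C(Nc1cccc(Nc2ncc(F)c(Nc3ccc(F)cc3)n2)c1)c1cccc([N+](=O)[O-])c1` gives 15100 nM
Compound 2 `O=C(Nc1cccc(Nc2ncc(F)c(Nc3ccc(F)cc3)n2)c1)c1ccncc1` gives 5280 nM

Going by the values given here, compound 2 has the lower of the two numbers, and it stands at 5280 nM in this assay as the better of only two measured compounds. Compound 3 `O=C(NCCO)c1cccc(Nc2ncc(F)c(Nc3ccc(F)cc3)n2)c1` is still unmeasured and carries (2-hydroxyethyl)carbamoyl in place of ((pyridin-4-yl)carbonyl)amino on an aromatic carbon, meta to a large group ((2-hydroxyethyl)carbamoyl in place of ((pyridin-4-yl)carbonyl)amino on an aromatic carbon). Among the compounds with values here, one measured step bears on this change, namely a 2.9-fold lower number from compound 1 to compound 2 (0.46 log units; beyond the scatter) in which pyridin-4-yl took the place of 3-nitrophenyl on a carbonyl carbon. Within the data shown here, that step exchanged one ring for another, and no measured compound shows the ring lost altogether. A modest step is therefore expected, and more likely toward a higher number, since compound 2 starts from the lower value. The expected change is a 2.1-fold higher number from compound 2 to compound 3 (0.32 log units; beyond the scatter) as an estimate only. For compound 3 the estimated value is 11000 nM with an expected range from 3500 nM to 35000 nM in this assay here.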

Compound 3, concentration for 50% growth inhibition: 12400 nM
For compound 3 the middle estimate is 1.1-fold (0.05 log units) below the measured one; the range from low to high includes it.
By their numbers in this assay, from the lowest: compound 2; then compounds 3 and 1 (each within the scatter of the next).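

Going by these compounds alone, the earlier step only exchanged one ring for another, whereas here the ring leaves altogether: in this assay the change to (2-hydroxyethyl)carbamoyl gives a 2.3-fold higher number from compound 2 to compound 3 (0.37 log units; beyond the scatter) as the first measured step with no ring in this group. The ring is not the only difference, since the amide also enters as carbamoyl in place of carbonylamino, and this single step cannot divide its size between the two changes. No measurement available here gives a reason for the step.

Going by these compounds, it remains open whether pyridin-4-yl on a carbamoyl link would behave as it does on the carbonylamino link. The compounds shown also leave open how a longer chain, an amine or a carboxylic acid would compare with the 2-hydroxyethyl chain.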